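Replacing the sulfonyl group on the ring nitrogen

The compounds below may be only part of what the source reports. "The series", "measured", "known", "first", "only" and "open" are said of these compounds alone.

In a functional assay on MGC-803 cells (Homo sapiens) for cytotoxicity, read by MTT assay, with a stated time of 48 h (on this read-out higher numbers stand for weaker inhibition and lower numbers for stronger inhibition), compound 1 `O=C(c1ccccc1Cl)N1N=C(c2cc3ccccc3oc2=O)CC1c1ccccc1` gives 6640 nM and compound 2 `Cc1ccc(S(=O)(=O)N2N=C(c3cc4ccccc4oc3=O)CC2c2ccccc2)cc1` gives 50200 nM, the higher of the two numbers. Compound 3 `CCCNCC(=O)N1N=C(c2cc3ccccc3oc2=O)CC1c1ccccc1` follows from compound 2 by placing ((propylamino)methyl)carbonyl in place of (4-methylphenyl)sulfonyl on an amine nitrogen in a ring. For the measured compounds named here, one measured step bears on this change at the same place, a modest one: a 7.6-fold higher number from compound 1 to compound 2 (0.88 log units; beyond the scatter), with (4-methylphenyl)sulfonyl in place of (2-chlorophenyl)carbonyl. Compound 3 again has a carbonyl at that nitrogen, as compound 1 does, so a step towards lower numbers of similar or somewhat smaller size is expected. Going by the values given here, no measured compound carries a propylamino chain, so the uncertainty is wide. The expected step is a 5.6-fold lower number from compound 2 to compound 3 (0.75 log units; beyond the scatter). For compound 3 the estimated value is 9000 nM, with an expected range from 2500 nM to 35000 nM.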

Compound 3, half-maximal inhibitory concentration: 4880 nM
For compound 3 the middle estimate is 1.8-fold (0.27 log units) above the measured one; low and high end bracket the measured number.
By their numbers in this assay, from the lowest: compounds 3 and 1 (each within the scatter of the next); then compound 2.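

In this assay, (4-methylphenyl)sulfonyl leaving the amine nitrogen in the ring for ((propylamino)methyl)carbonyl gives a 10-fold lower number from compound 2 to compound 3 (1.01 log units; beyond the scatter) and brings a second carbonyl-linked group to this place, one with no ring. On the carbonyl carbon, (propylamino)methyl in place of 2-chlorophenyl gives a 1.4-fold lower number from compound 1 to compound 3 (0.13 log units; within the scatter) and so leaves the two groups unseparated by this read-out, although one carries an aromatic ring and the other an open chain with a hydrogen-bond donor. Nothing on hand explains either step.

Open, as far as these compounds go, is whether the amide-linked chain depends on its amine hydrogen, which a dimethylamino group in place of propylamino would test, and how a longer chain would read. Also open, from the compounds shown here alone, is whether the higher number of compound 2 follows the sulfonyl or its 4-methylphenyl group, which a propylsulfonyl group would help separate.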